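Compound 3 to compound 4: methyl to ethyl

A few compounds are considered here, and "the series" means these few. Any claim that something is new, unique, unknown or untested is made for them only; others in the source may bear on it.

In a physicochemical assay for metabolic stability, read by LC-MS, in simulated gastric fluid, with a stated time of 15 min, tested at 50 uM (a higher number here means that more of the compound is left, a lower number that less of the compound is left), compound 1 (`O=C(OCc1ccccc1)c1coc(-c2ccccc2)n1`) gives 1.8% and compound 2 (`CCC(=O)c1ccccc1OC(=O)c1coc(-c2ccccc2)n1`) gives 1.8%. Compound 3 (`Cc1ccccc1OC(=O)c1coc(-c2ccccc2)n1`) gives 1.5% and stands within the scatter of both.

The next change leads to compound 4 (`CCc1ccccc1OC(=O)c1coc(-c2ccccc2)n1`): methyl in place of hydrogen on a saturated chain carbon bound to an aromatic carbon.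

Among the compounds with values here, two measured steps bear on it. The step of a number 0.3 percentage points lower from compound 1 to compound 3 (within the scatter) exchanged benzyl for 2-methylphenyl, and the step of a number 0.3 percentage points lower from compound 2 to compound 3 (within the scatter) exchanged propanoyl for methyl. Neither leaves the scatter in this assay, so no shift beyond the scatter is expected here.

The expected step is a number 0.1 percentage points higher from compound 3 to compound 4 (within the scatter). For compound 4 the estimated value is 1.6%, with an expected range from 0.5% to 4%.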

Compound 4, percent of the compound remaining: 2.1%
Compound 4: middle estimate off by 0.5 percentage points, on the low side; the range from low to high includes it.
By their numbers in this assay, from the lowest: compounds 3, 1, 2 and 4 (each within the scatter of the next).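

In this assay, extending methyl to ethyl on the saturated chain carbon bound to an aromatic carbon gives a step within the scatter (a number 0.6 percentage points higher from compound 3 to compound 4 (within the scatter)). The step of a number 0.3 percentage points higher from compound 2 to compound 4 (within the scatter) also stays within the scatter, so neither change at this place separates compound 4 from compound 2 or compound 3. No supporting data bear on this result.

Going by these compounds, whether a longer chain at this place would move the number beyond the scatter remains open. The same holds for an amine or a carboxylic acid there.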